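A few compounds are considered here, and "the series" means these few. Any claim that something is new, unique, unknown or untested is made for them only; others in the source may bear on it.

Measured so far in an assay on isolated protein (urine) for inhibition of Myeloperoxidase (Homo sapiens), with a stated time of 5 min; on this read-out higher numbers stand for weaker inhibition and lower numbers for stronger inhibition:
- compound 1, `CCCc1c[nH]c2ccc(F)cc12`: > 100 nM
- compound 2, `N#CCCCc1c[nH]c2ccc(F)cc12`: 63 nM
- compound 3, `NCCCCc1c[nH]c2ccc(C(=O)O)cc12`: "not active" (no number reported)

Compound 1 stands at a limit of this assay, not at a number: its entry of > 100 nM is the limit of > 100 nM in this assay, at which 1 of the 3 values shown sits. Compound 3 is reported only as "not active" (no number reported), without a number, so nothing can be said of its distance from the other two. Among the compounds with values here, compound 2 is the one compound of the three with a measured number, 63 nM.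

The unmeasured compound is compound 4, `NCCSCCc1c[nH]c2ccc(F)cc12`. Against compound 1 the change is (2-aminoethyl)sulfanyl in place of methyl on a saturated chain carbon, two bonds along the chain from an aromatic carbon.

Within the data shown here, only one measured step exists, an at least 1.5-fold lower number from compound 1 to compound 2 (0.20 log units; that floor lies within the scatter), and it concerns a different change at a different place on the chain: a cyano group three bonds along the chain, not a sulfur-linked aminoethyl chain two bonds along. Its floor lies within the scatter, so it gives no firm direction. Compound 3, which also carries a chain ending in an amine, was reported without a number, but it differs from compound 1 in two places, so its entry cannot be read as a step.

The expectation for compound 4 therefore rests on little; compound 4 is estimated at 250 nM, with a range of 50 nM to 1500 nM. Against compound 1 this estimate means a step that the limit leaves unreadable from compound 1 to compound 4, with a real chance that this assay again reports only a limit.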

Compound 4, half-maximal inhibitory concentration: 4 nM
For compound 4 the middle estimate is 63-fold (1.80 log units) above the measured one, and the stated range ends above it.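

In this assay, within the data shown here, (2-aminoethyl)sulfanyl in place of methyl on a saturated chain carbon, two bonds along the chain from an aromatic carbon, gives an at least 25-fold lower number from compound 1 to compound 4 (1.39 log units; beyond the scatter), the first step that lies beyond the scatter. Against cyanomethyl at the same place, the same group gives a 16-fold lower number from compound 2 to compound 4 (1.20 log units; beyond the scatter), a step between two measured numbers, so this place on the chain clearly responds to what it carries. The size of the step from the methyl compound remains a floor and not a measured distance, because compound 1 stands at a limit: the limit of > 100 nM in this assay, at which 1 of the 4 values shown sits.

Whether the sulfur, the terminal amine or both account for the step stays open; a methylsulfanyl group, a (2-aminoethyl)oxy group or an all-carbon chain ending in an amine at the same place would separate them. Compound 3 also ends in an amine but is reported as not active without a number and differs from compound 4 in more than one place, so a carboxylic acid on the core cannot be judged from it.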